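Removing the acetyl of compound 2: expected maximal response

The source may hold more compounds than are shown below. What is called first, only, known or untested is meant among the compounds shown, and "the series" means these compounds.

Measured so far:
- compound 1 `CCS(=O)(=O)Nc1cccc(Cc2c[nH]cn2)c1C`: in a functional assay on Urethra with Alpha-1A adrenergic receptor (Oryctolagus cuniculus) as the target (on this read-out lower numbers stand for smaller maximal responses and higher numbers for larger maximal responses), compound 1 gives 69%.
- compound 2 `CC(=O)Nc1cccc2c1CCCC2c1c[nH]cn1`: in this assay compound 2 gives 70%.

Compound 2 holds the higher of the two numbers, but its gap to compound 1 lies within the scatter, so the two compounds cannot be told apart on this read-out. Going by the values given here, both share an anilide-type arrangement on the core, and nothing among the measured pairs shows what removing such a group does.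

The next compound, compound 3 `Nc1cccc2c1CCCC2c1c[nH]cn1`, differs from compound 2 in one place: hydrogen in place of acetyl on a nitrogen on an aromatic ring. Among the compounds with values here, no measured pair carries this change, so no measured step is available to lean on. The change is small in atom count and leaves the rest of compound 2 untouched, so the expectation is a step in this assay that stays within the scatter, in no certain direction. Compound 3 is therefore expected to give about 68% in this assay, with a range from 50% to 85%. The estimated step of a number 2 percentage points lower from compound 2 to compound 3 (within the scatter) is expected to be small.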

Compound 3, largest response reached (reported as efficacy), in percent of the reference or control that the assay uses: 84%
Compound 3: middle estimate off by 16 percentage points, on the low side; the range from low to high includes it.
By their numbers in this assay, from the lowest: compounds 1 and 2 (each within the scatter of the next); then compound 3.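

Going from acetamido to amino in this assay gives a number 14 percentage points higher from compound 2 to compound 3 (beyond the scatter), the first measured step in the series, and it shows that the maximal response can move beyond the scatter through a change at this nitrogen on an aromatic ring. The acetyl is therefore not required for the response seen with compound 2, and the free amino form of the shared core retains a larger response. Nothing available explains this step.

A single pair cannot separate the effect of the free amino group from the simple loss of acetyl, and a methyl amine, a methanesulfonyl or a longer acyl chain such as propionyl on the same nitrogen would help to decide this. As far as these compounds go, whether the same change has a similar effect on the core of compound 1 also remains open.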